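Three limits and a fourth analogue on Vero cells

This account rests on a few compounds, and the source may have more. Where it says the series, first, only, none or still open, it means among the compounds named here.

Measured so far in an ADME assay on Vero cells (Chlorocebus sabaeus) for cytotoxicity, read by MTT assay, with a stated time of 72 h; a lower number here means a stronger inhibitor, a higher number a weaker inhibitor:
compound 1 `O=C(c1ccncc1)N1N=C(c2cc3ccccc3o2)CC1c1ccccc1O` gives > 195000 nM, a limit of the assay.
compound 2 `COc1ccccc1C1CC(c2cc3ccccc3o2)=NN1C(=O)c1ccncc1` gives > 202000 nM, a limit of the assay.
compound 3 `O=C(c1ccncc1)N1N=C(c2cc3ccccc3o2)CC1c1ccccc1Cl` gives > 210000 nM, a limit of the assay.

Compound 3 therefore stands only at a limit, and the two other values are limits as well. The steps a step that the two limits leave unreadable from compound 1 to compound 2, a step that the two limits leave unreadable from compound 1 to compound 3 and a step that the two limits leave unreadable from compound 2 to compound 3 all run between two limits and carry no readable size. Compound 4 `COc1ccc(C2CC(c3cc4ccccc4o3)=NN2C(=O)c2ccncc2)cc1` differs from compound 3 by 4-methoxyphenyl in place of 2-chlorophenyl on a saturated ring carbon. For the measured compounds named here, no measured step of readable size bears on this change, so in this assay no step beyond the scatter is expected in either direction. Compound 4 is expected to come back as a limit again, which is what a number no higher from compound 3 to compound 4 (the limit leaves the size open) expresses. Compound 4 is estimated at 210000 nM, between 150000 nM and 400000 nM.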

Compound 4, half-maximal inhibitory concentration: > 200000 nM
Compound 4: a limit, no number; the forecaster's own chance of this, stated with the estimate: 85%; the middle value is on the limit's open side.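

In this assay compound 4 gives > 200000 nM, a limit, so its steps from compound 1, compound 2 and compound 3 cannot be read. The compounds shown leave open what actual half-maximal value any of the four has.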